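The compounds below may be only part of what the source reports. "The series", "measured", "known", "first", "only" and "open" are said of these compounds alone.

Working notes on the series. In an assay on CHO cells for displacement of a labelled ligand from adenosine receptor A1 (Homo sapiens), read by scintillation counting, with a stated time of 3 h (on this read-out higher numbers stand for weaker inhibition and lower numbers for stronger inhibition), compound 1 `Cc1nc(N)c2nc(-c3ccccc3)sc2n1` gives 34 nM. Going by the values given here, compound 2 `COc1cccc(-c2nc(N)c3nc(-c4ccccc4)sc3n2)c1` gives 176 nM in this assay, and the one step recorded so far, a 5.2-fold higher number from compound 1 to compound 2 (0.71 log units; beyond the scatter), comes from putting 3-methoxyphenyl in place of methyl on an aromatic carbon. Among the compounds with values here, on the two numbers in hand compound 2 therefore stands highest, with compound 1 as its only neighbour at the lower number.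

Compound 3 `Nc1nc(-c2ccco2)nc2sc(-c3ccccc3)nc12` is not yet measured in this assay. It differs from compound 2 by furan-2-yl in place of 3-methoxyphenyl on an aromatic carbon. Within the data shown here, no measured step covers an exchange of one aromatic group for another at this place; the only step available concerns methyl against 3-methoxyphenyl there, and it was modest. The expectation for compound 3 is drawn from that: because compound 1 gives 34 nM with the shortest group at this place, an aromatic group other than 3-methoxyphenyl is expected to fall near or somewhat below compound 2, a step of a 2.2-fold lower number from compound 2 to compound 3 (0.34 log units; beyond the scatter) in this assay. Compound 3 is therefore estimated at 80 nM, with a range of 20 nM to 320 nM.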

Compound 3, inhibition constant: 67 nM
The estimate for compound 3 lay 1.2-fold (0.08 log units) above the measured number, and the stated range covers the measured number.
By their numbers in this assay, from the lowest: compounds 1 and 3 (each within the scatter of the next); then compound 2.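

Notes on this position in this assay: furan-2-yl in place of 3-methoxyphenyl gives a 2.6-fold lower number from compound 2 to compound 3 (0.42 log units; beyond the scatter) and so provides the first measured exchange of one aromatic group for another here, showing that the higher number with 3-methoxyphenyl does not follow merely from having an aromatic ring at this place. Furan-2-yl in place of methyl gives a 2.0-fold higher number from compound 1 to compound 3 (0.29 log units; within the scatter) and so does not separate these two groups, whereas 3-methoxyphenyl in place of methyl gives a 5.2-fold higher number from compound 1 to compound 2 (0.71 log units; beyond the scatter) and stands apart among the three groups shown. Nothing on hand gives a reason for this difference between the groups.

With the ring and its substituent changing together, the compounds shown leave open whether the higher number belongs to the six-membered aromatic ring or to its methoxy group, a question that plain phenyl at this place would address. Going by these compounds, how an amine, a carboxylic acid or a longer chain such as n-butyl would read at this place also remains open.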